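Methyl for Trifluoromethyl: A Small Step Expected

The compounds below may be only part of what the source reports. "The series", "measured", "known", "first", "only" and "open" are said of these compounds alone.

Of the compounds shown here, three built on a shared core have been tested in a functional assay on HeLa cells (Homo sapiens) for antiproliferative activity, read by MTT assay, with a stated time of 48 h; on this read-out higher numbers stand for weaker inhibition and lower numbers for stronger inhibition. Compound 1 `Cc1ccc2[nH]c(-c3cn(-c4ccccc4)nc3-c3ccc(F)cc3)nc2c1` gives 3630 nM, compound 2 `Fc1ccc(-c2nn(-c3ccccc3)cc2-c2nc3cc(C(F)(F)F)ccc3[nH]2)cc1` gives 3520 nM, and compound 3 `COc1ccc(-c2nn(-c3ccccc3)cc2-c2nc3cc(C(F)(F)F)ccc3[nH]2)cc1` gives 2760 nM; all three values lie within the usual scatter of one another, so no order among them can be read. Compound 2 and compound 1 differ by methyl in place of trifluoromethyl on an aromatic carbon, a step of a 1.0-fold higher number from compound 2 to compound 1 (0.01 log units; within the scatter). Compound 2 and compound 3 differ by methoxy in place of fluoro on an aromatic carbon, a step of a 1.3-fold lower number from compound 2 to compound 3 (0.11 log units; within the scatter). Compound 4 `COc1ccc(-c2nn(-c3ccccc3)cc2-c2nc3cc(C)ccc3[nH]2)cc1` has not yet been measured in this assay; it differs from compound 3 by methyl in place of trifluoromethyl on an aromatic carbon. Among the compounds with values here, this is the same change as the one from compound 2 to compound 1, made at the same place, and that earlier step stayed within the scatter. Because the same change gave a 1.0-fold higher number from compound 2 to compound 1 (0.01 log units; within the scatter), the expected step here is a 1.0-fold higher number from compound 3 to compound 4 (0.01 log units; within the scatter). Compound 4 is therefore expected to give about 2800 nM in this assay, with a likely range from 1400 nM to 5600 nM.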

Compound 4, half-maximal inhibitory concentration: 3290 nM
The estimate for compound 4 lay 1.2-fold (0.07 log units) below the measured number; the measured number falls inside the stated range.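

Methyl in place of trifluoromethyl gave a 1.2-fold higher number from compound 3 to compound 4 (0.08 log units; within the scatter) in this assay, and this step matches the one seen earlier: the same change on two cores in this assay, a 1.0-fold higher number (0.01 log units; within the scatter) from compound 2 to compound 1 and a 1.2-fold higher number (0.08 log units; within the scatter) from compound 3 to compound 4, 1.2-fold (0.06 log units) apart, within the scatter of two such steps. Methoxy in place of fluoro gave a 1.1-fold lower number from compound 1 to compound 4 (0.04 log units; within the scatter), and it too matches its earlier counterpart: the same change on two cores in this assay, a 1.3-fold lower number (0.11 log units; within the scatter) from compound 2 to compound 3 and a 1.1-fold lower number (0.04 log units; within the scatter) from compound 1 to compound 4, 1.2-fold (0.06 log units) apart, within the scatter of two such steps. Across these four compounds, each change therefore stayed within the scatter on both cores, but this shows only that neither step moved the number measurably, not that a change with a real effect would carry from one core to another, and two cores are too few to speak for the wider series.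

The compounds shown leave open whether another group at the place of methyl or trifluoromethyl, such as an amine, a carboxylic acid or a longer chain, would produce a step beyond the scatter. They also leave open whether such a step would keep its size from one core to another.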